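The source may hold more compounds than are shown below. What is called first, only, known or untested is meant among the compounds shown, and "the series" means these compounds.

Working notes on the series. The shared core carries an alkyne substituent that is varied across the set. Compound 1 `NC(=O)c1cc(Cl)c2c(Cl)c(C#CC3CCCO3)n([C@H]3CCCNC3)c2n1` in a functional assay on KG-1 cells (Homo sapiens) for antiproliferative activity (a higher number here means that more compound is needed for the effect, a lower number that less compound is needed), gives 223 nM; 91 nM (2 entries); the spread between its two entries the several entries of compound 1 in this assay, 223 nM; 91 nM (2 entries) gives a sense of the repeat scatter here. Compound 2 `NC(=O)c1cc(Cl)c2c(Cl)c(C#CCN3CCCC3=O)n([C@H]3CCCNC3)c2n1` in this assay gives 178 nM. Compound 3 `CC(O)C#Cc1c(Cl)c2c(Cl)cc(C(N)=O)nc2n1[C@H]1CCCNC1` in this assay gives 147 nM, the lowest of the two single numbers, with compound 2 nearest; the step of a 1.2-fold lower number from compound 2 to compound 3 (0.08 log units; within the scatter) is within the scatter, and compound 1 stands apart only with its pair of entries and no single number.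

Compound 4 `CC(C)(C#N)CC#Cc1c(Cl)c2c(Cl)cc(C(N)=O)nc2n1[C@H]1CCCNC1` differs from compound 3 by 2-cyano-2-methylpropyl in place of 1-hydroxyethyl on a triple-bonded carbon. Within the data shown here, the only measured step that bears on it is the swap at the same place, on a triple-bonded carbon, a 1.2-fold lower number from compound 2 to compound 3 (0.08 log units; within the scatter), which was within the scatter. On that basis no movement beyond the scatter is expected, so the step of a 1.0-fold higher number from compound 3 to compound 4 (0.01 log units; within the scatter) is estimated as flat. Compound 4 is therefore expected to give about 150 nM in this assay, within 50 nM to 450 nM.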

Compound 4, half-maximal effective concentration: 113 nM
Beside the measured number, compound 4's estimate is 1.3-fold (0.12 log units) above it; measured number inside the range.
By their numbers in this assay, from the lowest: compounds 4, 3 and 2 (each within the scatter of the next).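

With 2-cyano-2-methylpropyl in place of 1-hydroxyethyl on a triple-bonded carbon, the group grows from 3 to 6 heavy atoms and goes from 1 hydrogen-bond donor to 0, yet this assay records only a 1.3-fold lower number from compound 3 to compound 4 (0.11 log units; within the scatter) for this change. The comparison with the 2-oxopyrrolidin-1-yl group gives a 1.6-fold lower number from compound 2 to compound 4 (0.20 log units; within the scatter) and also stays within the scatter, so compounds 2, 3 and 4 do not separate at this place despite their different substituents. Neither the larger group nor the loss of the donor therefore gives a shift that can be told from the repeat spread: the several entries of compound 1 in this assay, 223 nM; 91 nM (2 entries).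

The compounds shown leave open whether an amine or a carboxylic acid at this place would move the number beyond the scatter. They also leave open whether a much longer chain would do so.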